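A few compounds are considered here, and "the series" means these few. Any claim that something is new, unique, unknown or untested is made for them only; others in the source may bear on it.

In a functional assay on MCF7 cells (Homo sapiens) for cytotoxicity, read by MTT assay, with a stated time of 72 h (a lower number here means a stronger inhibitor, a higher number a weaker inhibitor), compound 3 `Cc1cc(S(=O)(=O)/N=C(\N)n2nccc2-c2ccccc2)c(SCc2ccc(C(F)(F)F)cc2)cc1Cl` gives 25000 nM, the second highest of the three numbers measured. Its nearest neighbour is compound 2 `Cc1cc(-c2ccccc2)n(/C(N)=N/S(=O)(=O)c2cc(C)c(Cl)cc2SCc2ccc(C(F)(F)F)cc2)n1` at 16000 nM, and the furthest is compound 1 `Cc1cccc(CSc2cc(Cl)c(C)cc2S(=O)(=O)/N=C(\N)n2nccc2-c2ccccc2)c1` at 47000 nM; both steps, a 1.6-fold higher number from compound 2 to compound 3 (0.19 log units; within the scatter) and a 1.9-fold lower number from compound 1 to compound 3 (0.27 log units; within the scatter), stay within the scatter. Compound 4 `Cc1ccc(CSc2cc(Cl)c(C)cc2S(=O)(=O)/N=C(\N)n2nccc2-c2ccccc2)cc1` differs from compound 3 by methyl in place of trifluoromethyl on an aromatic carbon. The step that bears on this is a 1.9-fold lower number from compound 1 to compound 3 (0.27 log units; within the scatter), where a 3-methylphenyl group gave way to the trifluoromethyl-bearing ring; compound 4 largely reverses that change, carrying a 4-methylphenyl group instead. Because a 1.9-fold lower number from compound 1 to compound 3 (0.27 log units; within the scatter) stayed within the scatter, the expected step of a 1.4-fold higher number from compound 3 to compound 4 (0.15 log units; within the scatter) is a slight rise in the number, not beyond the scatter. Compound 4 is estimated at 35000 nM, ranging from 15000 nM to 80000 nM.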

Compound 4, half-maximal inhibitory concentration: 21000 nM
For compound 4 the middle estimate is 1.7-fold (0.22 log units) above the measured one, and the stated range covers the measured number.
By their numbers in this assay, from the lowest: compounds 2, 4, 3 and 1 (each within the scatter of the next, the first and the last beyond it).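

In this assay the exchange of trifluoromethyl for methyl on this ring gives a 1.2-fold lower number from compound 3 to compound 4 (0.08 log units; within the scatter) so at this position the two groups cannot be told apart. Placing the methyl differently, with 4-methylphenyl in place of 3-methylphenyl, gives a 2.2-fold lower number from compound 1 to compound 4 (0.35 log units; beyond the scatter) and this modest step is the first single change in the series to pass the scatter. Nothing available explains either step. Still open, on these data alone, is whether an amine or a carboxylic acid at this position on the ring would give a number clearly different from those of compound 3 and compound 4.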